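Acetoxymethyl in place of chloro, from compound 2 to compound 4

The source may report more compounds than this note shows. Statements on the series, on what has been measured and on what is new or still open speak of the compounds shown alone.

Three measured compounds share one core and differ only in the aryl group on the carbonyl carbon. Compound 1 `O=C(c1ccn(-c2ccc3c(c2)B(O)OC3)c1)c1ccc(Cl)cc1Cl` carries a 2,4-dichlorophenyl, compound 2 `O=C(c1ccc(Cl)cc1)c1ccn(-c2ccc3c(c2)B(O)OC3)c1` a 4-chlorophenyl, and compound 3 `COc1ccccc1C(=O)c1ccn(-c2ccc3c(c2)B(O)OC3)c1` a 2-methoxyphenyl. In an ADME assay on L929 cells (Mus musculus) for cytotoxicity, read by resazurin assay, with a stated time of 72 h (a lower number here means a stronger inhibitor, a higher number a weaker inhibitor), compound 1 gives > 10 ug/mL, which is a limit of the assay and not a number. In this assay compound 2 gives > 10 ug/mL, again a limit. In this assay compound 3 gives > 10 ug/mL, also a limit. Compound 2 thus stands at the limit together with the two other values, as the limit of > 10 ug/mL in this assay, at which 3 of the 3 values shown sit, records. The steps a step that the two limits leave unreadable from compound 1 to compound 2, a step that the two limits leave unreadable from compound 1 to compound 3 and a step that the two limits leave unreadable from compound 2 to compound 3 are accordingly of unreadable size.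

Compound 4 `CC(=O)OCc1ccc(C(=O)c2ccn(-c3ccc4c(c3)B(O)OC4)c2)cc1` differs from compound 2 by acetoxymethyl in place of chloro on an aromatic carbon. For the measured compounds named here, the steps that bear on this change, hydrogen for chloro and the two aryl swaps, all run between limits, so no size can be drawn from them; what they do show is that none of the three aryl groups brings the value into the measurable range. Compound 4 is therefore expected to remain at the limit as well, with the step that the limit leaves unreadable from compound 2 to compound 4 expected to be small. The estimate for compound 4 in this assay is 20 ug/mL, within 10 ug/mL to 60 ug/mL.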

Compound 4, half-maximal inhibitory concentration: 10 ug/mL
Beside the measured number, compound 4's estimate is 2.0-fold (0.30 log units) above it; low and high end bracket the measured number.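

With acetoxymethyl on the aromatic carbon para to a large group, compound 4 gives 10 ug/mL in this assay, the only value among the compounds shown that is a number and not a limit. Compound 2 gives > 10 ug/mL, which is a limit of the assay and not a number. Acetoxymethyl in place of chloro thus gives a number no higher from compound 2 to compound 4 (the limit leaves the size open), the one step here that has a direction, while the other steps cannot be read and the values still lie mostly at one limit: the limit of > 10 ug/mL in this assay, at which 3 of the 4 values shown sit.

The compounds shown leave open how large this step is, and whether a real change in cytotoxicity lies behind it at all, since one side of it is only a limit. They also leave open what a hydroxymethyl, a carboxylic acid or an amine at this same place on the aromatic ring would give in this assay, and so whether any other group there would also yield a number.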